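Series notes: three measured compounds, one pending

A few compounds are considered here, and "the series" means these few. Any claim that something is new, unique, unknown or untested is made for them only; others in the source may bear on it.

Measured so far in an assay on MDA-MB-231 cells for displacement of a labelled ligand from C-X-C chemokine receptor type 4 (Homo sapiens), read by fluorescence and microscopy, with stated times of 10 min and 30 min; a lower number here means that less compound is needed, a higher number that more compound is needed for the effect:
compound 1 `COc1ccccc1C(=O)NCc1ccc(CNS(=O)(=O)c2cccc3ccccc23)cc1` gives > 1000 nM, a limit of the assay rather than a number
compound 2 `COc1ccccc1C(=O)NCc1ccc(CNS(=O)(=O)c2cccc(Cl)c2)cc1` gives 1000 nM
compound 3 `Cc1ccccc1C(=O)NCc1ccc(CNS(=O)(=O)c2cccc3ccccc23)cc1` gives 100 nM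

Two single changes connect these. From compound 1 to compound 3 the difference is methyl in place of methoxy on an aromatic carbon, and the step is an at least 10-fold lower number from compound 1 to compound 3 (1.00 log units; beyond the scatter). As far as these compounds go, from compound 1 to compound 2 the difference is 3-chlorophenyl in place of naphthalen-1-yl on a sulfonyl sulfur, and the step is a number no higher from compound 1 to compound 2 (the limit leaves the size open); the size stays open because the limit of > 1000 nM in this assay, at which 1 of the 3 values shown sits, is all that compound 1 gives. Compound 3 gives 100 nM and compound 2 gives 1000 nM.

Compound 4 `Cc1ccccc1C(=O)NCc1ccc(CNS(=O)(=O)c2cccc(Cl)c2)cc1` is not yet measured. It differs from compound 3 by 3-chlorophenyl in place of naphthalen-1-yl on a sulfonyl sulfur, the same change that runs from compound 1 to compound 2, with the place described in the same words. Among the compounds with values here, the only gauge for this change is the step from compound 1 to compound 2, which reads as a number no higher from compound 1 to compound 2 (the limit leaves the size open) and sets no size. The core of compound 4 is that of compound 3, and the cores of compound 3 and compound 1 differ by methyl in place of methoxy on an aromatic carbon.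

For compound 4 the expected step from its parent is a 2.0-fold higher number from compound 3 to compound 4 (0.30 log units; within the scatter), resting on the open-ended reading of a number no higher from compound 1 to compound 2 (the limit leaves the size open). Compound 4 is therefore estimated at 200 nM in this assay, with a range from 60 nM to 1000 nM expected.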

Compound 4, effective concentration (reported as EC, without a stated level of effect): 100 nM
Estimate against measurement, compound 4: 2.0-fold (0.30 log units) above; the range from low to high includes it.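

In this assay, 3-chlorophenyl in place of naphthalen-1-yl on a sulfonyl sulfur now has one readable outcome, no change at the digits printed from compound 3 to compound 4 (within the scatter), but this does not establish that the change behaves alike on both cores: the same change on two cores in this assay, a number no higher (the limit leaves the size open) from compound 1 to compound 2 and no change at the digits printed (within the scatter) from compound 3 to compound 4; the limit leaves it open whether they differ

The earlier step cannot be read for size, so the result gives one sized instance of the change rather than a rule for the series: the limit of > 1000 nM in this assay, at which 1 of the 4 values shown sits.

The methyl-for-methoxy change, which links the two cores, reads as a 10-fold lower number from compound 2 to compound 4 (1.00 log units; beyond the scatter), and on both cores that change goes the same way, with no compound shown against this, though the size of any gap between the two steps stays unsettled: the same change on two cores in this assay, an at least 10-fold lower number (1.00 log units; beyond the scatter) from compound 1 to compound 3 and a 10-fold lower number (1.00 log units; beyond the scatter) from compound 2 to compound 4; the limit leaves it open whether they differ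

The compounds shown carry only naphthalen-1-yl or 3-chlorophenyl on the sulfonyl sulfur and only methyl or methoxy on the aromatic carbon, so nothing here tells how far these readings extend to other groups. As far as these compounds go, an amine or a carboxylic acid in place of the 3-chlorophenyl, or an ethyl group or a longer chain in place of the methyl, remains open, as does a numerical reading for the core of compound 1 with naphthalen-1-yl.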